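This account rests on a few compounds, and the source may have more. Where it says the series, first, only, none or still open, it means among the compounds named here.

In an ADME assay on the whole organism (lung, Mus musculus) for pharmacokinetics, read by LC-MS, at a dose of 30 mg/kg by the oral route (a higher number here means more compound in the circulation at the dose given, a lower number less compound in the circulation), compound 1 `NCc1cc(Oc2cccc(C(=O)NCCS(N)(=O)=O)c2)nc(C(F)(F)F)c1` gives 540 nM, compound 2 `CONC(=O)c1cccc(Oc2cc(CN)cc(C(F)(F)F)n2)c1` gives 8780 nM, and compound 3 `NCc1cc(Oc2cccc(C(=O)NC[C@@H](O)CO)c2)nc(C(F)(F)F)c1` gives 1920 nM, the second highest of the three numbers. Every step measured so far alters the group on the amide, and each moved the number beyond the scatter: a 16-fold higher number from compound 1 to compound 2 (1.21 log units; beyond the scatter), a 3.6-fold higher number from compound 1 to compound 3 (0.55 log units; beyond the scatter), and a 4.6-fold lower number from compound 2 to compound 3 (0.66 log units; beyond the scatter). Compound 4 `NCc1cc(Oc2cccc(C(=O)N3CC[C@@H](O)C3)c2)nc(C(F)(F)F)c1` differs from compound 3 in that same region: 3-hydroxypyrrolidin-1-yl in place of (2,3-dihydroxypropyl)amino on a carbonyl carbon. The amide substituent has shifted the result each time, and compound 2 gave the highest number, so a modest rise is expected for compound 4, about a 1.8-fold higher number from compound 3 to compound 4 (0.26 log units; within the scatter). Compound 4 is therefore estimated at 3500 nM, with a range from 1200 nM to 10000 nM.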

Compound 4, maximal plasma concentration: 9130 nM
Compound 4: the middle estimate sits 2.6-fold (0.42 log units) below what was measured; the measured number falls inside the stated range.
By their numbers in this assay, from the lowest: compound 1; then compound 3; then compounds 2 and 4 (each within the scatter of the next).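

In this assay, 3-hydroxypyrrolidin-1-yl in place of (2,3-dihydroxypropyl)amino on the carbonyl carbon gives a 4.8-fold higher number from compound 3 to compound 4 (0.68 log units; beyond the scatter). Going by these compounds alone, this is the first ring at this position, and it shows that a ring carrying a single hydroxyl can reach the level of the small methoxyamino group, with a 1.0-fold higher number from compound 2 to compound 4 (0.02 log units; within the scatter), and stay far from (2-sulfamoylethyl)amino, with a 17-fold higher number from compound 1 to compound 4 (1.23 log units; beyond the scatter). Nothing available explains these shifts. As far as these compounds go, whether the ring's hydroxyl matters, and how unsubstituted pyrrolidin-1-yl or a morpholine ring would compare, remains open.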